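The compounds below may be only part of what the source reports. "The series", "measured", "known", "first", "only" and "open" are said of these compounds alone.

Three compounds share one core, and in an assay on HEK293 cells for agonist activity at transient receptor potential cation channel subfamily M member 8 (Homo sapiens), read by fluorescence and calcium flux, with a stated time of 15 min (a lower number here means that less compound is needed, a higher number that more compound is needed for the effect), they span a wide range. Compound 1 `Cc1ccc(OCC(=O)N(Cc2cccs2)c2ncccn2)cc1` gives 3700 nM. Compound 2 `Cc1ccc(OCC(=O)N(Cc2cccs2)c2ccnn2C)cc1` gives 422 nM, a drop of an 8.8-fold lower number from compound 1 to compound 2 (0.94 log units; beyond the scatter). Compound 3 `Cc1ccc(OCC(=O)N(Cc2cccs2)c2ccn[nH]2)cc1` gives 0.2 nM, the lowest number of the three; the change of a 2100-fold lower number from compound 2 to compound 3 (3.32 log units; beyond the scatter) and the change of a 19000-fold lower number from compound 1 to compound 3 (4.27 log units; beyond the scatter) are both large and well beyond the scatter, so compound 3 stands clearly apart from the other two.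

Compound 4 `Cc1ccc(OCC(=O)N(Cc2cccs2)c2ccccc2)cc1` is not yet measured. It differs from compound 3 in one place: phenyl in place of 1H-pyrazol-5-yl on an amide-type nitrogen. The ring that leaves carries the hydrogen-bond donor whose removal by a methyl cost a 2100-fold lower number from compound 2 to compound 3 (3.32 log units; beyond the scatter) in reverse, and the ring that enters has no donor or acceptor at all, resembling in that respect compound 1 rather than compound 3. A large rise in the number is therefore expected for compound 4 in this assay, on the order of a 40000-fold higher number from compound 3 to compound 4 (4.60 log units; beyond the scatter). The expected value for compound 4 is 8000 nM, within a range from 800 nM to 80000 nM.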

Compound 4, half-maximal effective concentration: 23 nM
Estimate against measurement, compound 4: 350-fold (2.54 log units) above; the measured number lies below the stated range.
By their numbers in this assay, from the lowest: compound 3; then compound 4; then compound 2; then compound 1.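

Replacing the 1H-pyrazol-5-yl ring with phenyl shows that a ring with no hydrogen-bond donor or acceptor can still give a low number at this place on the amide-type nitrogen, although the step of a 120-fold higher number from compound 3 to compound 4 (2.06 log units; beyond the scatter) in this assay is large. The phenyl ring also outperforms both nitrogen-containing rings that lack the ring hydrogen, with an 18-fold lower number from compound 2 to compound 4 (1.26 log units; beyond the scatter) and a 160-fold lower number from compound 1 to compound 4 (2.21 log units; beyond the scatter) as the two steps. Loss of the donor therefore does not by itself bring the high numbers of compound 1 and compound 2.

Still open, on these data alone, is whether a phenyl ring carrying a hydroxyl or an amine would move the number closer to that of compound 3. A 1H-imidazol-2-yl ring at the same place would test how much the arrangement of the ring nitrogens matters. No measurement available here explains why these rings differ.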